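The source may hold more compounds than are shown below. What is called first, only, known or untested is meant among the compounds shown, and "the series" means these compounds.

Of the compounds shown here, three have been measured in a functional assay on HCT-15 cells (Homo sapiens) for antiproliferative activity, read by MTT assay, with a stated time of 72 h; on this read-out lower numbers stand for stronger inhibition and higher numbers for weaker inhibition.

Compound 1, `COc1cc(-c2nccn2CC(C)C)cc(OC)c1OC`, sits at the limit > 100000 nM of that assay, not a number.
Compound 2, `COc1cc(-c2nccn2Cc2ccccc2)cc(OC)c1OC`, likewise sits at the limit > 100000 nM.
Compound 3, `COc1cccc(-n2ccnc2-c2cc(OC)c(OC)c(OC)c2)c1`, gives 17100 nM.

Among the measured compounds shown here, compound 3 therefore holds the only numerical value among the three; the other two are limits, as the limit of > 100000 nM in this assay, at which 2 of the 3 values shown sit, states. Both measured steps run toward compound 3: an at least 5.8-fold lower number from compound 1 to compound 3 (0.76 log units; beyond the scatter) and an at least 5.8-fold lower number from compound 2 to compound 3 (0.76 log units; beyond the scatter), each at least modest, though their full size is hidden behind the limit.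

Compound 4, `COc1ccc(-n2ccnc2-c2cc(OC)c(OC)c(OC)c2)cc1`, is built from the same atoms as compound 3 joined differently: 4-methoxyphenyl in place of 3-methoxyphenyl on an aromatic nitrogen. Neither measured step bears directly on this change, since both concern swapping a saturated chain for an aryl group on the ring nitrogen rather than moving the methoxy around that aryl ring. With no guidance beyond this, the step from compound 3 is expected to fall within the scatter, a 1.2-fold higher number from compound 3 to compound 4 (0.07 log units; within the scatter). Compound 4 is accordingly estimated at 20000 nM, expected between 7000 nM and 60000 nM.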

Compound 4, half-maximal inhibitory concentration: 1300 nM
The estimate for compound 4 lay 15-fold (1.19 log units) above the measured number; the whole stated range lies above it.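

Moving the methoxy from the 3-methoxyphenyl to the 4-methoxyphenyl on the aromatic nitrogen, with the same atoms joined differently, gives a 13-fold lower number from compound 3 to compound 4 (1.12 log units; beyond the scatter); at this place the number therefore depends on where the methoxy sits on the aryl ring, not only on an aryl group being present. The 4-methoxyphenyl in place of benzyl gives an at least 76-fold lower number from compound 2 to compound 4 (1.88 log units; beyond the scatter), and in place of isobutyl it gives an at least 76-fold lower number from compound 1 to compound 4 (1.88 log units; beyond the scatter). Both of these steps start from a limit of the assay and not a number, so their full size cannot be read: the limit of > 100000 nM in this assay, at which 2 of the 4 values shown sit.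

The aryl groups shown carry only a methoxy, so it remains open whether a chlorine, a hydroxyl or a dimethylamino group in its place would keep the number of compound 4. Going by these compounds, whether a plain phenyl on that nitrogen would do so is equally open.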